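Permeability notes on a quinoline series: chloro removal

The source may hold more compounds than are shown below. What is called first, only, known or untested is meant among the compounds shown, and "the series" means these compounds.

Measured so far:
- compound 1 `COc1ccc(F)cc1CNCCCNc1ccnc2cc(Cc3ccc(F)cc3Cl)ccc12`: 23 10^-6 cm/s
- compound 2 `Fc1ccc(Cc2ccc3c(NCCCNCc4ccco4)ccnc3c2)c(Cl)c1`: 23 10^-6 cm/s

In an ADME assay for permeability, using PAMPA, with a stated time of 30 min, at pH 7.4 (on this read-out lower numbers stand for lower permeability and higher numbers for higher permeability), compound 1 gives 23 10^-6 cm/s and compound 2 gives 23 10^-6 cm/s, so compound 1 stands level with compound 2 at the digits shown. Among the measured compounds shown here, the one measured step, no change at the digits printed from compound 1 to compound 2 (within the scatter), exchanges furan-2-yl for 5-fluoro-2-methoxyphenyl on a saturated chain carbon bound to an amine nitrogen and produces no change beyond the scatter in this assay.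

Compound 3 `COc1ccc(F)cc1CNCCCNc1ccnc2cc(Cc3ccc(F)cc3)ccc12` is not yet measured. It differs from compound 1 in one place: hydrogen in place of chloro on an aromatic carbon, read one bond further out as 2-chloro-4-fluorobenzyl to 4-fluorobenzyl. For the measured compounds named here, no measured step touches this part of the molecule; the step from compound 1 to compound 2 alters the other end of the shared core. Going by the values given here, there is therefore no measured step that bears on this change, and the expectation rests only on the two values so far, which sit together in this assay.

For compound 3 in this assay a step of a 1.2-fold lower number from compound 1 to compound 3 (0.06 log units; within the scatter) is expected, that is none beyond the scatter. The estimate for compound 3 is 20 10^-6 cm/s, with a range from 10 10^-6 cm/s to 40 10^-6 cm/s.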

Compound 3, apparent permeability: 23 10^-6 cm/s
Estimate against measurement, compound 3: 1.2-fold (0.06 log units) below; measured number inside the range.
By their numbers in this assay, from the lowest: compounds 1, 2 and 3 (each within the scatter of the next).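

In this assay, among the compounds shown here, this is the first reading at the aromatic carbon ortho to a large group and meta to the fluoro group, and it gives no change at the digits printed from compound 1 to compound 3 (within the scatter). Compounds 1 and 2 spoke only to the group on the saturated chain carbon, whereas this pair shows that, with 5-fluoro-2-methoxyphenyl held at that end, 2-chloro-4-fluorobenzyl and 4-fluorobenzyl are not told apart on this read-out. No measurement offers an explanation for this result, so it stands as an observation about this one pair.

On these data alone, whether hydrogen in place of chloro reads the same with furan-2-yl at the chain end, as in compound 2, remains open. Also open, as far as these compounds go, is how this aromatic carbon responds to groups other than chloro and hydrogen, such as a carboxylic acid, an amine or a methoxy group.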